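Bromo to nitro on the carbonyl-bearing aromatic ring

The source may report more compounds than this note shows. Statements on the series, on what has been measured and on what is new or still open speak of the compounds shown alone.

Of the compounds shown here, three built on one shared core have been tested in a functional assay on A549 cells (Homo sapiens) for inhibition, read by MTT assay, with a stated time of 48 h, tested at 10 uM; a higher number here means more inhibition of growth at the concentration tested, a lower number less inhibition of growth. Compound 1 `O=C(/C=C/c1ccc(OCc2cn(Cc3cccc(Br)c3)nn2)cc1)c1ccc(Br)cc1` gives 44%, compound 2 `O=C(/C=C/c1ccc(OCc2cn(Cc3cccc(F)c3)nn2)cc1)c1ccc(Br)cc1` gives 37%, and compound 3 `O=C(/C=C/c1ccc(OCc2cn(Cc3ccc(F)cc3)nn2)cc1)c1ccc(Br)cc1` gives 43%. Compound 2 has the lowest of the three numbers, yet the gaps to its neighbours, a number 6 percentage points higher from compound 2 to compound 3 (within the scatter) and a number 1 percentage points lower from compound 1 to compound 3 (within the scatter), fall inside the scatter.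

Compound 4 `O=C(/C=C/c1ccc(OCc2cn(Cc3cccc(F)c3)nn2)cc1)c1ccc([N+](=O)[O-])cc1` differs from compound 2 in this way: nitro in place of bromo on an aromatic carbon. For the measured compounds named here, no measured step changes that ring; the only halogen swap seen, a number 7 percentage points lower from compound 1 to compound 2 (within the scatter), sits on a different ring and stays within the scatter. The step therefore expected is a number 1 percentage points higher from compound 2 to compound 4 (within the scatter), nothing beyond the scatter. Compound 4 is estimated at 38%, with a range from 24% to 52%.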

Compound 4, percent growth inhibition at one concentration: 33%
Beside the measured number, compound 4's estimate is 5 percentage points above it, and the stated range covers the measured number.
By their numbers in this assay, from the lowest: compounds 4, 2, 3 and 1 (each within the scatter of the next, the first and the last beyond it).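

For the compounds shown here, the swap of 4-bromophenyl to 4-nitrophenyl in this assay gives a number 4 percentage points lower from compound 2 to compound 4 (within the scatter) and is the first step seen at this position. One heavy atom gives way to three, with two hydrogen-bond acceptors added, and the step stays within the scatter. No measured evidence bears on this result. As far as these compounds go, what an amine or a carboxylic acid in place of the bromo would give stays open. Also open, from the compounds shown here alone, is whether the nitro step would read the same with the 3-bromophenyl group of compound 1 in place of 3-fluorophenyl.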